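The source may hold more compounds than are shown below. What is called first, only, known or untested is meant among the compounds shown, and "the series" means these compounds.

Largest response reached in an assay on CHO cells with metabotropic glutamate receptor 2 (Homo sapiens) as the target, read by FLIPR; a higher number here means a larger maximal response, a lower number a smaller maximal response:

compound 1 `Cn1c(CN2CCC(c3ccccc3)CC2)nc2ccccc21`: 89%
compound 2 `Cn1c(CN2CCC(c3ccc(Cl)cc3)CC2)nc2ccccc21`: 91%
compound 3 `Cn1c(CN2CCC(c3ccccc3C(F)(F)F)CC2)nc2ccccc21`: 94%

On these three numbers compound 3 stands highest, but its nearest neighbour is compound 2, lower by a margin that lies within the scatter, and compound 1 lies only a little further off, again within the scatter. No ordering among the three is supported.

Compound 4 `Cn1c(CN2CCC(c3ccccc3F)CC2)nc2ccccc21` differs from compound 3 by fluoro in place of trifluoromethyl on an aromatic carbon.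

Among the compounds with values here, two measured steps bear on substitution at that part of the structure: a number 2 percentage points higher from compound 1 to compound 2 (within the scatter) and a number 5 percentage points higher from compound 1 to compound 3 (within the scatter). Both are within the scatter, so neither a chloro nor a trifluoromethyl group entering on the aromatic carbon moved the largest response beyond noise. Removing most of the trifluoromethyl group and leaving a fluoro in its place is therefore expected to give no step beyond the scatter in this assay; the expected step is a number 4 percentage points lower from compound 3 to compound 4 (within the scatter).

For compound 4 the estimated largest response is 90%, with a range from 80% to 100%.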

Compound 4, largest response reached (Emax), in percent of the reference or control that the assay uses: 91%
For compound 4 the middle estimate is 1 percentage points below the measured one, within the range that was stated.
By their numbers in this assay, from the lowest: compounds 1, 2, 4 and 3 (each within the scatter of the next).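

In this assay, the place on an aromatic carbon ortho to a large group tolerates a much smaller group than trifluoromethyl: the exchange for fluoro gives a number 3 percentage points lower from compound 3 to compound 4 (within the scatter) and, against the unsubstituted compound, fluoro in place of hydrogen gives a number 2 percentage points higher from compound 1 to compound 4 (within the scatter) as well. Exchanging the whole aryl group, 2-fluorophenyl in place of 4-chlorophenyl, gives no change at the digits printed from compound 2 to compound 4 (within the scatter) and so separates neither the groups nor their places on the ring in this read-out. Nothing on hand offers an explanation for this flat picture.

As far as these compounds go, whether an amine, a carboxylic acid or a methoxy group at this place would move the largest response beyond the scatter remains open. Also open, from the compounds shown here alone, is whether any change away from the aromatic ring, such as a longer chain in place of the methyl on the shared core, would do so.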